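The source may hold more compounds than are shown below. What is called first, only, known or untested is meant among the compounds shown, and "the series" means these compounds.

Measured in an ADME assay on the whole organism (plasma) for pharmacokinetics, with Rattus norvegicus as the target, at a dose of 5 mg/kg by the oral route; a lower number here means less compound in the circulation, a higher number more compound in the circulation at the dose given:
compound 1, `CC[C@H](C)[C@@H]1C(=O)N[C@H](C2Cc3ccccc3C2)C(=O)N1[C@@H](C(=O)N(C)C)c1cc(C)cnc1C`: 1370 ng.h/mL
compound 2, `CC[C@H](C)[C@@H]1C(=O)N[C@H](C2Cc3ccccc3C2)C(=O)N1[C@@H](C(=O)N1CCOCC1)c1ccc(C)nc1`: 1450 ng.h/mL
compound 3, `CCC(CC)[C@@H]1C(=O)N[C@H](C2Cc3ccccc3C2)C(=O)N1[C@@H](C(=O)N1CCOCC1)c1ccc(C)nc1C`: 2330 ng.h/mL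

On these numbers compound 2 holds the second highest of the three in this assay; the nearest is compound 1 and the furthest is compound 3, and both gaps lie within the usual scatter, so the three measured compounds cannot be told apart on exposure.

Compound 4, `CC[C@@H](C)[C@@H]1C(=O)N[C@H](C2Cc3ccccc3C2)C(=O)N1[C@@H](C(=O)N1CCOCC1)c1ccc(C)nc1`, is not yet measured. Set against compound 2 the change is the two compounds have the same atoms and bonds and differ only in configuration as drawn: 1 of 4 stereo elements differ; a stereocentre at a saturated chain carbon is drawn S in compound 2 and R in compound 4. Among the compounds with values here, no pair of measured compounds differs in this single place, so no measured step shows what such a change does. The three measured compounds differ from one another in several places and still sit within the scatter of each other, which gives no sign of a large swing from a single change of configuration. The step is expected to be small, a 1.2-fold lower number from compound 2 to compound 4 (0.08 log units; within the scatter), most likely none beyond the scatter, with a slight lean downward as the untested direction. Compound 4 is therefore estimated at 1200 ng.h/mL, with a range from 500 ng.h/mL to 2800 ng.h/mL.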

Compound 4, area under the concentration-time curve: 1590 ng.h/mL
Compound 4: middle estimate off by 1.3-fold (0.12 log units), on the low side, within the range that was stated.
By their numbers in this assay, from the lowest: compounds 1, 2, 4 and 3 (each within the scatter of the next).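

In this assay, the change from S to R at the saturated chain carbon gives a 1.1-fold higher number from compound 2 to compound 4 (0.04 log units; within the scatter). Within the data shown here, this is the first step that can be read at a single place, and it shows no difference in exposure that stands clear of the scatter for this pair, so the drawn configuration at this carbon does not separate the two compounds at this oral dose. No other structural change enters the comparison: the fact that compounds 2 and 4 differ only in the configuration as drawn

Among these compounds, only this one pair tests the carbon, so the same inversion on the background of compound 1 remains open, as do the other stereo elements. Also open, on these data alone, is how exposure would respond if a cyclohexyl group or a tert-butyl group stood in place of the branched chain.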